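This account rests on a few compounds, and the source may have more. Where it says the series, first, only, none or still open, it means among the compounds named here.

Measured in a functional assay on HCT-116 cells (Homo sapiens) for inhibition, read by MTT assay, with a stated time of 48 h; on this read-out lower numbers stand for stronger inhibition and higher numbers for weaker inhibition:
- Compound 1 `COc1cc(-c2cc(-c3cccc([N+](=O)[O-])c3)nc(-c3ccccc3)n2)cc(OC)c1OC`: > 25000 nM (a limit)
- Compound 2 `COc1cc(-c2cc(-c3ccccc3)nc(-c3ccccc3)n2)cc(OC)c1OC`: 9950 nM

Within the data shown here, compound 2, at 9950 nM, holds the only true number in this assay. Compound 1 stands at the limit of > 25000 nM in this assay, at which 1 of the 2 values shown sits.

Compound 3 `COc1ccc(-c2cc(-c3cc(OC)c(OC)c(OC)c3)nc(-c3ccccc3)n2)cc1` has not yet been measured. It differs from compound 2 by one change, methoxy in place of hydrogen on an aromatic carbon, turning phenyl into 4-methoxyphenyl.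

Among the measured compounds shown here, only one measured step bears on this, an at least 2.5-fold lower number from compound 1 to compound 2 (0.40 log units; beyond the scatter), where hydrogen replaces nitro. It shows that a single group on an aromatic carbon can move this read-out beyond the scatter. However, it concerns nitro, not methoxy, so it is weak guidance on both size and direction.

No step beyond the scatter is therefore expected, and the estimate is a 1.3-fold lower number from compound 2 to compound 3 (0.12 log units; within the scatter).

For compound 3 the expected value is 7500 nM, with an estimated range from 2500 nM to 22000 nM.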

Compound 3, half-maximal inhibitory concentration: 4780 nM
For compound 3 the middle estimate is 1.6-fold (0.20 log units) above the measured one; the measured number falls inside the stated range.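

In this assay, among these compounds, the earlier compounds showed only that taking a nitro group off this ring lowers the number; now a group added to the same ring lowers it too, with a 2.1-fold lower number from compound 2 to compound 3 (0.32 log units; beyond the scatter). So a bare phenyl is not the best of the rings shown, and a substituent here is not harmful as such: what counts is which group it is, where it sits, or both, since 3-nitrophenyl and 4-methoxyphenyl differ in both respects, and exchanging them gives an at least 5.2-fold lower number from compound 1 to compound 3 (0.71 log units; beyond the scatter). The value of compound 1 is a limit, not a true number, so that step has only a lower bound: the limit of > 25000 nM in this assay, at which 1 of the 3 values shown sits.

The compounds shown leave open whether methoxy itself matters or whether another group at this place, such as an amine, a hydroxyl or a longer ethoxy chain, would lower the number further. They also leave open what methoxy would do elsewhere on this ring.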